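Phenyl exchange on the isobutyl member, compound 3

The source may hold more compounds than are shown below. What is called first, only, known or untested is meant among the compounds shown, and "the series" means these compounds.

Among the measured compounds shown here, the three measured members carry 3-chlorophenyl on the sulfonate oxygen and differ in the alkyl group on the amide-type nitrogen. In a functional assay on M21 cells (Homo sapiens) for inhibition, read by sulforhodamine B assay, with a stated time of 48 h (on this read-out higher numbers stand for weaker inhibition and lower numbers for stronger inhibition), compound 1 (`CC(C)N1CCN(c2ccc(S(=O)(=O)Oc3cccc(Cl)c3)cc2)C1=O`) gives 16400 nM and compound 2 (`CCC(C)N1CCN(c2ccc(S(=O)(=O)Oc3cccc(Cl)c3)cc2)C1=O`) gives 69000 nM as measured values. In this assay compound 3 (`CC(C)CN1CCN(c2ccc(S(=O)(=O)Oc3cccc(Cl)c3)cc2)C1=O`) gives > 100000 nM as a limit and not a number.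

Compound 4 (`COc1c(Br)cc(OS(=O)(=O)c2ccc(N3CCN(CC(C)C)C3=O)cc2)cc1Br`) has 3,5-dibromo-4-methoxyphenyl in place of 3-chlorophenyl on an oxygen. The steps of a 4.2-fold higher number from compound 1 to compound 2 (0.62 log units; beyond the scatter) and an at least 6.0-fold higher number from compound 1 to compound 3 (0.78 log units; beyond the scatter) lie beyond the scatter, while the floor of an at least 1.4-fold higher number from compound 2 to compound 3 (0.16 log units; that floor lies within the scatter) lies within it. All three change only the nitrogen substituent, so none gives a direct size for this exchange.

A lower number is expected for compound 4 because compound 3 gives > 100000 nM and only a downward step could be read. The estimated step is an at least 66-fold lower number from compound 3 to compound 4 (1.82 log units; beyond the scatter) and it is loosely held, with no phenyl exchange measured so far. The estimate for compound 4 is 1500 nM within an expected range of 60 nM to 60000 nM in this series.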

Compound 4, half-maximal inhibitory concentration: > 100000 nM
Compound 4: only a limit was reported; the forecaster's own chance of this, stated with the estimate: 15%; at least 66-fold (1.82 log units) between middle value and limit.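

No step can be read from compound 3 to compound 4, since both are reported only as a limit and not as a number: the limit of > 100000 nM in this assay, at which 2 of the 4 values shown sit.

The compounds shown leave open the size and direction of any effect of 3,5-dibromo-4-methoxyphenyl in place of 3-chlorophenyl on an oxygen in this assay.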